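The source may hold more compounds than are shown below. What is called first, only, known or untested is meant among the compounds shown, and "the series" means these compounds.

Three compounds sharing the core of compound 1, `O=C(/C=C/CN1CCCCC1)Nc1ccccc1`, have been measured in an ADME assay for pharmacokinetics, read by LC-MS, in phosphate buffer, with a stated time of 120 min, at pH 7.4, tested at 1 uM, in the presence of a further agent that is not named here; a higher number here means that the compound lasts longer, a lower number that the compound disappears faster. Compound 2, `CN(C)CC/C=C/C(=O)Nc1ccccc1`, gives 7.38 h, the highest of the three numbers. Compound 1 gives 2.95 h, and compound 3, `CCN(CC)C/C=C/C(=O)Nc1ccccc1`, gives 2.83 h. The step of a 2.5-fold higher number from compound 1 to compound 2 (0.40 log units; beyond the scatter) and the step of a 2.6-fold lower number from compound 2 to compound 3 (0.42 log units; beyond the scatter) are both modest yet beyond the scatter, while the step of a 1.0-fold lower number from compound 1 to compound 3 (0.02 log units; within the scatter) lies within it, so compound 1 and compound 3 cannot be told apart on these numbers.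

Compound 4, `O=C(/C=C/C(F)F)Nc1ccccc1`, has not yet been measured in this assay. It differs from compound 2 in one place: difluoromethyl in place of 2-(dimethylamino)ethyl on a double-bonded chain carbon bound to a double-bonded chain carbon. For the measured compounds named here, every measured step swaps one amine for another amine, whereas this change takes the amine away altogether and brings in difluoromethyl, so none of the measured steps bears on it directly. Those steps were modest, and the three measured numbers lie close together, which leaves the expectation loose. For compound 4 the expected half-life in this assay is 3.5 h, with a range from 1 h to 12 h. This estimate means a step of a 2.1-fold lower number from compound 2 to compound 4 (0.32 log units; beyond the scatter), expected to be downward, though its size is uncertain.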

Compound 4, half-life: 0.733 h
For compound 4 the middle estimate is 4.8-fold (0.68 log units) above the measured one; measured number outside the range, below it.
By their numbers in this assay, from the lowest: compound 4; then compounds 3 and 1 (each within the scatter of the next); then compound 2.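

For the compounds shown here, the step of a 10-fold lower number from compound 2 to compound 4 (1.00 log units; beyond the scatter) in this assay is the first here that takes the amine away altogether, and it reaches further than a step that only exchanges one amine for another, such as a 2.5-fold higher number from compound 1 to compound 2 (0.40 log units; beyond the scatter). This place on the chain can therefore shift the half-life by more than the amine swaps alone suggested, and the change is not a single simple one: 2-(dimethylamino)ethyl, with 5 heavy atoms including a nitrogen and a hydrogen-bond acceptor, gives way to difluoromethyl, with 3 heavy atoms including two fluorines and no hydrogen-bond acceptor. Nothing measured here accounts for the lower number, so the result stands as an observation without an explanation.

The compounds shown leave open whether the lower half-life goes with the loss of the amine, the arrival of the fluorines or the shorter group. A plain butyl chain, which has neither nitrogen nor fluorine, and a methyl or trifluoromethyl group at this place would help pull these apart, while a carboxylic acid would show how a different kind of group behaves here.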